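Replacing a Benzyl with a Bicyclic Amine: Cytotoxicity Outlook

The source may hold more compounds than are shown below. What is called first, only, known or untested is meant among the compounds shown, and "the series" means these compounds.

compound 1, `COc1ccc2[nH]c(C(=O)N3CC(=O)N(Cc4ccccc4)[C@@H](CCc4ccccc4)C3)cc2c1`: > 30000 nM
compound 2, `Cc1ccc2[nH]c(C(=O)N3CC(=O)N(Cc4ccccc4)[C@@H](CN4CCC5(CCC5)CC4)C3)cc2c1`: 7800 nM
compound 3, `COc1ccc2[nH]c(C(=O)N3CC(=O)N(Cc4ccccc4)[C@@H](CN4CCN(c5ccc(F)cc5)CC4)C3)cc2c1`: > 30000 nM

Of the compounds shown here, three on a shared core have been tested in an ADME assay on Vero cells (Chlorocebus sabaeus) for cytotoxicity, with a stated time of 7 days; on this read-out lower numbers stand for higher toxicity in this test and higher numbers for lower toxicity in this test. For compound 1 the reading is a limit of the assay, > 30000 nM. Compound 3 likewise returns a limit, > 30000 nM. Compound 2 gives a number, 7800 nM. Compound 1 therefore stands at the limit of > 30000 nM in this assay, at which 2 of the 3 values shown sit, and only compound 2 yields a value inside the measured range.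

Compound 4, `COc1ccc2[nH]c(C(=O)N3CC(=O)N(Cc4ccccc4)[C@@H](CN4CC5CC5C4)C3)cc2c1`, has not yet been measured. It differs from compound 1 in one place: a group of 6 heavy atoms (5 carbon, 1 nitrogen; one three-membered non-aromatic ring of carbon only, one five-membered non-aromatic ring with 1 hetero atom) in place of a group of 7 heavy atoms (7 carbon; one six-membered aromatic ring of carbon only), on a saturated chain carbon bound to a saturated ring carbon. Among the compounds with values here, no step between measured compounds is available, so the size of the change in this assay can only be anticipated. With two of the three readings sitting at the limit, compound 4 is expected to stay close to that limit, and the estimated step of an at least 1.2-fold lower number from compound 1 to compound 4 (0.07 log units; that floor lies within the scatter) is expected to be small or none beyond the scatter. Compound 4 is estimated at 25000 nM, with a range from 7000 nM to 60000 nM.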

Compound 4, half-maximal cytotoxic concentration: 13800 nM
Beside the measured number, compound 4's estimate is 1.8-fold (0.26 log units) above it, and the stated range covers the measured number.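

In this assay, within the data shown here, replacing benzyl with the group holding a three-membered carbon ring and a five-membered ring with one nitrogen gives the first readable step at this place, on a saturated chain carbon bound to a saturated ring carbon: an at least 2.1-fold lower number from compound 1 to compound 4 (0.33 log units; beyond the scatter). This shows that the group carried here can bear on the read-out, as compound 4 gives a number inside the measured range. The reading for compound 1, > 30000 nM, is a limit of the assay, so this step has only a floor and its full size cannot be told: the limit of > 30000 nM in this assay, at which 2 of the 4 values shown sit.

The compounds shown leave open whether the nitrogen or the three-membered ring goes with the lower number. They also leave open how a morpholine or a simple diethylamino group would read at this place.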